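Permeability of acyl-sulfonamide variants on a shared core

The source may hold more compounds than are shown below. What is called first, only, known or untested is meant among the compounds shown, and "the series" means these compounds.

Measured compounds:
- Compound 1, `O=C(NS(=O)(=O)c1ccc(F)cc1)c1ccc(Nc2nc(NC3(c4ccc(Cl)cc4)CC3)nc(OCC(F)(F)F)n2)cc1`: 193 nm/s
- Compound 2, `CC(C)S(=O)(=O)NC(=O)c1ccc(Nc2nc(NC3(c4ccc(Cl)cc4)CC3)nc(OCC(F)(F)F)n2)cc1`: 31 nm/s
- Compound 3, `CC(=O)NCCS(=O)(=O)NC(=O)c1ccc(Nc2nc(NC3(c4ccc(Cl)cc4)CC3)nc(OCC(F)(F)F)n2)cc1`: 7 nm/s

In a physicochemical assay for permeability, using PAMPA, at pH 7.4 (a lower number here means that the compound crosses the layer more slowly, a higher number that the compound crosses the layer faster), compound 1 gives the highest of the three numbers. Replacing its 4-fluorophenyl group changed the read-out each time: a 6.2-fold lower number from compound 1 to compound 2 (0.79 log units; beyond the scatter) and a 28-fold lower number from compound 1 to compound 3 (1.44 log units; beyond the scatter), with a 4.4-fold lower number from compound 2 to compound 3 (0.65 log units; beyond the scatter) between the two replacements. Compound 4, `O=C(NS(=O)(=O)CCNCc1ccccc1)c1ccc(Nc2nc(NC3(c4ccc(Cl)cc4)CC3)nc(OCC(F)(F)F)n2)cc1`, has not yet been measured; it differs from compound 1 as follows: 2-(benzylamino)ethyl in place of 4-fluorophenyl on a sulfonyl sulfur. Like the change to compound 3, this change introduces a group with one hydrogen-bond donor and one acceptor on the sulfonyl sulfur, so the step to compound 3 is the closest guide. Compound 4 is therefore expected to show a 39-fold lower number from compound 1 to compound 4 (1.59 log units; beyond the scatter) in this assay, a large drop. The estimated value of compound 4 is 5 nm/s, with a range from 1 nm/s to 25 nm/s.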

Compound 4, apparent permeability: 49 nm/s
Beside the measured number, compound 4's estimate is 9.8-fold (0.99 log units) below it; the whole stated range lies below it.
By their numbers in this assay, from the lowest: compound 3; then compounds 2 and 4 (each within the scatter of the next); then compound 1.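

In this assay, chains on the sulfonyl sulfur that hold a nitrogen do not all behave alike: benzyl in place of acetyl on an amine nitrogen gives a 7.0-fold higher number from compound 3 to compound 4 (0.85 log units; beyond the scatter), a sizeable swing from one end of the chain. Against the other groups, 2-(benzylamino)ethyl gives a 3.9-fold lower number from compound 1 to compound 4 (0.60 log units; beyond the scatter), a smaller step than 2-acetamidoethyl gave, and a 1.6-fold higher number from compound 2 to compound 4 (0.20 log units; within the scatter), so it sits level with isopropyl. Nothing measured here explains these differences.

Open, on these data alone, is how a carboxylic acid or a longer chain on the sulfonyl sulfur would compare. Also open, as far as these compounds go, is whether a tertiary amine in that chain would read like compound 4.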